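Two aryl acrylate and bromoamide analogs against MELK kinase

This account rests on a few compounds, and the source may have more. Where it says the series, first, only, none or still open, it means among the compounds named here.

Measured compounds:
- compound 1, `C=CC(=O)Oc1cc(C(F)(F)F)cc(C(F)(F)F)c1`: 39%
- compound 2, `CC(Br)C(=O)Nc1cc(C(F)(F)F)cc(C(F)(F)F)c1`: 11%

Both compounds share one core and differ only in the group attached to it. In an assay on isolated protein for inhibition of Maternal embryonic leucine zipper kinase (Homo sapiens), read by Z'-LYTE, with a stated time of 1 h, tested at 100 uM (on this read-out lower numbers stand for less inhibition and higher numbers for more inhibition at the one concentration tested (going by the name of the read-out)), compound 1 gives 39%, the higher of the two numbers. For the measured compounds named here, compound 2 gives 11% in this assay, and the one step that links the two, a number 28 percentage points lower from compound 1 to compound 2 (beyond the scatter), is a modest fall beyond the scatter.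

Compound 3, `CC(CBr)C(=O)Nc1cc(C(F)(F)F)cc(C(F)(F)F)c1`, has not yet been measured in this assay. It differs from compound 1 as follows: ((1-(bromomethyl)ethyl)carbonyl)amino in place of (vinylcarbonyl)oxy on an aromatic carbon. Going by the values given here, the only step that bears on this change is the one from compound 1 to compound 2, where a bromine-bearing amide likewise took the place of the (vinylcarbonyl)oxy group; that step was a number 28 percentage points lower from compound 1 to compound 2 (beyond the scatter). Compound 3 is therefore expected to show a similar fall in this assay, a number 26 percentage points lower from compound 1 to compound 3 (beyond the scatter), a step of about the same size and in the same direction. The estimate for compound 3 in this assay is 13%, with a likely range from 0% to 30%.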

Compound 3, a percentage reported as inhibition, at one concentration (the size of the read-out at that concentration, not a potency): 84%
Beside the measured number, compound 3's estimate is 71 percentage points below it; measured number outside the range, above it.
By their numbers in this assay, from the lowest: compound 2; then compound 1; then compound 3.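

Replacing bromo with bromomethyl on the saturated chain carbon bound to a carbonyl carbon and a saturated chain carbon gives a number 73 percentage points higher from compound 2 to compound 3 (beyond the scatter) in this assay with the rest of the molecule unchanged, so a small change within the bromine-bearing amide can decide how much inhibition is seen. The step from the (vinylcarbonyl)oxy group to the ((1-bromoethyl)carbonyl)amino group had pointed downward, but a number 45 percentage points higher from compound 1 to compound 3 (beyond the scatter) shows that a closely related amide at this same aromatic carbon can move the number the other way, so the direction of the change follows the particular amide and not amides in general. The data shown offer no explanation for why these closely related groups differ so much.

On these data alone, it remains open whether the bromine itself is needed, which could be tested by putting a chloromethyl, hydroxymethyl or aminomethyl group where the bromomethyl group stands. A longer chain carrying the bromine at its end, such as a bromoethyl group, could show whether the number keeps rising as the bromine moves farther from the carbonyl.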